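Antiproliferative series: a methoxy step from compound 1

This account rests on a few compounds, and the source may have more. Where it says the series, first, only, none or still open, it means among the compounds named here.

Measured compounds
compound 1 `CCN1CCN(c2cc(C)c3cc(NC(=O)c4ccccc4)ccc3n2)CC1`: 18400 nM
compound 2 `Cc1cc(N(C)C)nc2ccc(NC(=O)c3ccc(Cl)c(Cl)c3)cc12`: > 50000 nM

In a functional assay on SK-BR-3 cells (Homo sapiens) for antiproliferative activity, read by MTT assay, with a stated time of 72 h (on this read-out higher numbers stand for weaker inhibition and lower numbers for stronger inhibition), compound 1 gives 18400 nM. For compound 2 this assay reports only a limit, > 50000 nM. The evidence on the measured values is the limit of > 50000 nM in this assay, at which 1 of the 2 values shown sits. Going by the values given here, compound 1 therefore carries the only numerical value in this assay; the other value is a limit, so no ordering of the two beyond that can be stated.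

Compound 3 `CCN1CCN(c2cc(C)c3cc(NC(=O)c4ccc(OC)cc4)ccc3n2)CC1` differs from compound 1 by methoxy in place of hydrogen on an aromatic carbon. Among the compounds with values here, no pair of measured compounds differing in one place is available, so the size of such a step in this assay has not been observed. The expectation is that the change from compound 1 to compound 3 gives a step within the usual scatter, with no clear direction, so that a 1.2-fold lower number from compound 1 to compound 3 (0.06 log units; within the scatter) is estimated as small. Compound 3 is expected to give about 16000 nM in this assay, with a range from 5000 nM to 50000 nM.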

Compound 3, half-maximal inhibitory concentration: 9000 nM
Beside the measured number, compound 3's estimate is 1.8-fold (0.25 log units) above it; measured number inside the range.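

In this assay, going by these compounds alone, a 2.0-fold lower number from compound 1 to compound 3 (0.31 log units; beyond the scatter) is the first step read between compounds that differ in one place, and it shows that a change on the benzoyl part of the molecule can move the number. Going from phenyl to 4-methoxyphenyl, the position para to a large group takes methoxy with a modest shift toward stronger inhibition rather than a loss, something the earlier compounds, which offered no such pair, could not show. This remains a single step at a single position, and nothing measured here bears on what lies behind it.

Going by these compounds, whether this shift is particular to methoxy or would also appear with another group on the same carbon remains open; hydroxy, a carboxylic acid or a primary amine there would help separate these possibilities, as would a longer chain such as butoxy. On these data alone, it is also open whether methoxy on another carbon of the same ring, or the same change made with a different group in place of the ethylpiperazine part of compound 1, would give a step of similar size and direction.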